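This account rests on a few compounds, and the source may have more. Where it says the series, first, only, none or still open, it means among the compounds named here.

For the measured compounds named here, in a functional assay on COLO 205 cells (Homo sapiens) for antiproliferative activity, read by MTT assay (a higher number here means a weaker inhibitor, a lower number a stronger inhibitor), only two compounds have been measured so far. Compound 1 `CC1(c2ccccc2)CN(S(=O)(=O)c2ccc3c(c2)CCCN3C(=O)C(F)(F)F)C(=O)N1` gives > 20000 nM, which is a limit of the assay and not a number. Compound 2 `CSc1ccc(NC(=O)N2CCCc3cc(S(=O)(=O)N4CC(C)(c5ccccc5)NC4=O)ccc32)cc1` gives > 20000 nM, which is also a limit. The whole record so far is the limit of > 20000 nM in this assay, at which 2 of the 2 values shown sit. Going by the values given here, the only measured step is a step that the two limits leave unreadable from compound 1 to compound 2, and it offers neither a size nor a direction to carry forward.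

Compound 3 `COc1ccc(NC(=O)N2CCCc3cc(S(=O)(=O)N4CC(C)(c5ccccc5)NC4=O)ccc32)cc1` differs from compound 2 in one small place: methoxy in place of methylsulfanyl on an aromatic carbon. Methoxy stands in place of methylsulfanyl on an aromatic carbon, para to a large group, and the rest of the structure stays the same. Among the compounds with values here, no measured step touches this group, so the data favour no direction, and no change beyond the usual scatter is expected in this assay. The expectation starts from compound 2 at > 20000 nM, and compound 3 may well be reported as a limit too. The expected size of this swap is a number no higher from compound 2 to compound 3 (the limit leaves the size open). For compound 3 the estimate is 20000 nM, with an expected range from 5000 nM to 40000 nM.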

Compound 3, half-maximal inhibitory concentration: > 20000 nM
Compound 3 ended at the assay's limit (the forecaster's own chance of this, stated with the estimate: 70%); the middle value lies on the limit itself.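

No step among compound 1, compound 2 and compound 3 can be read, since all three values are a limit of the assay and not a number: the limit of > 20000 nM in this assay, at which 3 of the 3 values shown sit.

The compounds shown leave open whether swapping methylsulfanyl for methoxy, or trifluoromethyl for either substituted phenylamino group, changes activity at all in this assay, and what change to the shared core would bring a value inside the measurable range.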